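A few compounds are considered here, and "the series" means these few. Any claim that something is new, unique, unknown or untested is made for them only; others in the source may bear on it.

In a functional assay on the whole organism for antagonist activity, with Mus musculus as the target (a higher number here means that more compound is needed for the effect, a lower number that less compound is needed), compound 1 `COC(=O)N(C)CC#CCN1CCCC1` gives > 10 mg/kg, which is a limit and not a number. Compound 2 `COC(=O)N(C)C(C)C#CCN1CCCC1` gives > 100 mg/kg, which is also a limit, so no exact value is available for either compound. Going by the values given here, the only measured step, a step that the two limits leave unreadable from compound 1 to compound 2, has no readable size and involves a different change. Compound 3 `COC(=O)N(C)C(C)C#CCN(C)C` has dimethylamino in place of pyrrolidin-1-yl on a saturated chain carbon bound to a triple-bonded carbon, dimethylamino in place of pyrrolidin-1-yl on a saturated chain carbon bound to a triple-bonded carbon. Among the compounds with values here, no measured step shows this change, so no clear shift is expected. The expected step is a number no higher from compound 2 to compound 3 (the limit leaves the size open). For compound 3, the estimated dose is 100 mg/kg, within an expected range of 30 mg/kg to 300 mg/kg.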

Compound 3, dose for half-maximal effect: > 100 mg/kg
Compound 3 ended at the assay's limit (the forecaster's own chance of this, stated with the estimate: 65%); the middle value lies on the limit itself.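

In this assay compound 3 gives > 100 mg/kg, which is a limit and not a number, as is the result for compound 2, so no step can be read between them. Going by these compounds, the exact doses of compounds 1, 2 and 3 remain open.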